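Side-chain exchange from compound 3 to compound 4

The source may hold more compounds than are shown below. What is called first, only, known or untested is meant among the compounds shown, and "the series" means these compounds.

Compound 3 `Cc1cc(C)cc(S(=O)(=O)c2c(C(=O)NCc3n[nH]c4ccccc34)[nH]c3ccc(Cl)cc23)c1` gives > 50700 nM in an ADME assay on MT4 cells (Homo sapiens) for cytotoxicity, read by MTT assay (on this read-out higher numbers stand for lower toxicity in this test and lower numbers for higher toxicity in this test), which is a limit and not a number. Compound 2 `Cc1cc(C)cc(S(=O)(=O)c2c(C(=O)NCc3cccc(N)c3)[nH]c3ccc(Cl)cc23)c1` is likewise known only by a limit, > 53400 nM. Going by the values given here, the only measured step is a step that the two limits leave unreadable from compound 2 to compound 3, so it offers no size to carry forward. Among the compounds with values here, compound 1 `Cc1cc(C)cc(S(=O)(=O)c2c(C(=O)NC(C)C(=O)NCCn3c(C)cnc3[N+](=O)[O-])[nH]c3ccc(Cl)cc23)c1` is the only compound with a number, 16000 nM. Compound 4 `Cc1cc(C)cc(S(=O)(=O)c2c(C(=O)NCC(=O)NCc3ccncn3)[nH]c3ccc(Cl)cc23)c1` has ((pyrimidin-4-yl)methyl)carbamoyl in place of 1H-indazol-3-yl on a saturated chain carbon bound to an amide-type nitrogen. No change beyond the scatter is expected, and the expected step is an at least 1.1-fold lower number from compound 3 to compound 4 (0.05 log units; that floor lies within the scatter). The low end of the range is set by compound 1 at 16000 nM. For compound 4 the estimate is 45000 nM, with an expected range of 16000 nM to 100000 nM.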

Compound 4, half-maximal cytotoxic concentration: > 48800 nM
Compound 4 gave a limit, no number (the forecaster's own chance of this, stated with the estimate: 60%); at least 1.0-fold (0.03 log units) between middle value and limit.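

Going by these compounds alone, compound 2, compound 3 and compound 4 are each known only by a limit, so no step among them can be read. The compounds shown leave open whether these side-chain exchanges change the read-out in this assay at all.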